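Methoxy for acetyl on the styryl-piperidine series

The source may report more compounds than this note shows. Statements on the series, on what has been measured and on what is new or still open speak of the compounds shown alone.

Among the compounds with values here, the shared core carries a piperidine joined through an alkene to a benzene ring; the three measured members differ only in the ring substituent. In a functional assay on A549 cells (Homo sapiens) for inhibition, read by MTT assay, with a stated time of 24 h (on this read-out lower numbers stand for stronger inhibition and higher numbers for weaker inhibition), compound 2 `CC(=O)c1ccc(/C=C/[C@@H]2CCCCN2)cc1` gives 3.69 ug/mL. Compound 1 `COc1ccccc1/C=C/[C@@H]1CCCCN1` gives 4.94 ug/mL in this assay, within the scatter of compound 2, so the two cannot be ordered. Compound 3 `Cc1ccc(/C=C/[C@@H]2CCCCN2)cc1` gives 8.56 ug/mL in this assay, and the step of a 2.3-fold higher number from compound 2 to compound 3 (0.37 log units; beyond the scatter) is the only one in the set that reaches beyond the scatter.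

Compound 4 `COc1ccc(/C=C/[C@@H]2CCCCN2)cc1` is not yet measured. It differs from compound 2 as follows: methoxy in place of acetyl on an aromatic carbon. Within the data shown here, no measured pair shows methoxy against acetyl at the same position, so the bearing evidence is indirect: removing the carbonyl-bearing substituent for methyl cost a modest step in a 2.3-fold higher number from compound 2 to compound 3 (0.37 log units; beyond the scatter), while a methoxy elsewhere on the ring, compound 1, sits at 4.94 ug/mL. A small rise in the number is therefore expected, a 1.6-fold higher number from compound 2 to compound 4 (0.21 log units; within the scatter), likely inside or just beyond the scatter. Compound 4 is estimated at 6 ug/mL, with a range from 3.5 ug/mL to 10.5 ug/mL.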

Compound 4, half-maximal inhibitory concentration: 4.33 ug/mL
The estimate for compound 4 lay 1.4-fold (0.14 log units) above the measured number; the measured number falls inside the stated range.
By their numbers in this assay, from the lowest: compounds 2, 4, 1 and 3 (each within the scatter of the next, the first and the last beyond it).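

In this assay, methoxy and acetyl at this place on the ring cannot be told apart (a 1.2-fold higher number from compound 2 to compound 4 (0.07 log units; within the scatter)). Methoxy also cannot be told apart from methyl at the same place (a 2.0-fold lower number from compound 3 to compound 4 (0.30 log units; within the scatter)), so compound 4 lies within the scatter of both neighbours, while acetyl and methyl remain separated (a 2.3-fold higher number from compound 2 to compound 3 (0.37 log units; beyond the scatter)) and that pair alone still shows a readable change at this place. Nothing measured here accounts for these numbers.

Going by these compounds, whether an amine or a carboxylic acid at this place would shift the number beyond the scatter of compound 4 stays open. On these data alone, a longer chain, such as ethoxy in place of methoxy, is equally open, so how much room for change this place allows remains undefined.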